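The source may report more compounds than this note shows. Statements on the series, on what has been measured and on what is new or still open speak of the compounds shown alone.

Working notes on the series. In an ADME assay on PC-3 cells (Homo sapiens) for cytotoxicity, read by WST assay, tested at 100 uM (a higher number here means more inhibition at the concentration tested (going by the name of the read-out), a lower number less inhibition), compound 1 `Cc1nc(-c2cccc(NC(=O)C3CCCN(C(=O)c4cc(C(F)(F)F)cc(C(F)(F)F)c4)C3)c2)cs1` gives 1%. Compound 3 `Cc1nc(-c2cccc(C(=O)N3CCCC(C(=O)Nc4ccc(Cl)cc4)C3)c2)cs1` gives 1% and compound 2 `COc1cccc(C(=O)N2CCCC(C(=O)Nc3ccc(Cl)cc3)C2)c1` gives 0%. Compound 1 is level with compound 3 at the digits shown, and together these two stand at the top of the three numbers; the gap from compound 1 to compound 2 is within the scatter. For the measured compounds named here, the only step between measured compounds that differ in one place is a number 1 percentage points higher from compound 2 to compound 3 (within the scatter), which lies within the scatter.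

Compound 4 `Cn1cnnc1-c1cccc(NC(=O)C2CCCN(C(=O)c3cc(C(F)(F)F)cc(C(F)(F)F)c3)C2)c1` differs from compound 1 by one change: 4-methyl-4H-1,2,4-triazol-3-yl in place of 2-methyl-1,3-thiazol-4-yl on an aromatic carbon

Going by the values given here, no measured step exchanges one five-membered aromatic ring for another, so the only guide is a number 1 percentage points higher from compound 2 to compound 3 (within the scatter), where a five-membered aromatic ring replaced methoxy and nothing moved beyond the scatter. Since all three measured numbers sit near zero, no step beyond the scatter is expected in this assay from compound 1 to compound 4. The estimate for compound 4 is 2%, with a range from -8% to 12%. This estimate means an expected a number 1 percentage points higher from compound 1 to compound 4 (within the scatter), within the scatter.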

Compound 4, a percentage reported as inhibition, at one concentration (the size of the read-out at that concentration, not a potency): 0%
Beside the measured number, compound 4's estimate is 2 percentage points above it; measured number inside the range.
By their numbers in this assay, from the lowest: compounds 2, 4, 1 and 3 (each within the scatter of the next).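

In this assay, for the compounds shown here, this is the first exchange of one five-membered aromatic ring for another, made on an aromatic carbon of the six-membered aromatic ring, meta to a large group, and it gives a number 1 percentage points lower from compound 1 to compound 4 (within the scatter). Here 4-methyl-4H-1,2,4-triazol-3-yl replaces 2-methyl-1,3-thiazol-4-yl, so sulfur leaves the ring, hetero atoms go from 2 to 3 and hydrogen-bond acceptors from 2 to 3, with no change in the read-out beyond the scatter. No measurement in hand bears on the reason for this result.

From the compounds shown here alone, whether a basic amine such as aminomethyl or a carboxylic acid at this position would shift the read-out beyond the scatter remains open. Also open, going by these compounds, is whether any change elsewhere in compound 1, such as replacing the two trifluoromethyl groups with methyl groups, would do so.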